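A few compounds are considered here, and "the series" means these few. Any claim that something is new, unique, unknown or untested is made for them only; others in the source may bear on it.

Compound 2 `CN(C)c1ccc2cc(NC(=O)CCc3ccc(C(F)(F)F)cc3)ccc2n1` sits at the lower end of the two single numbers in an assay on isolated protein for displacement of a labelled ligand from melanin-concentrating hormone receptor 1 (Homo sapiens); on this read-out lower numbers stand for stronger inhibition and higher numbers for weaker inhibition: there compound 2 gives 13 nM, while compound 1 `O=C(CCc1ccc(C(F)(F)F)cc1)Nc1ccc2nc(N3CCC(c4ccccc4)C3)ccc2c1` gives 25 nM, and the step of a 1.9-fold lower number from compound 1 to compound 2 (0.28 log units; within the scatter) is too small to stand out from the usual scatter. Compound 3 `O=C(CCc1ccc(C(F)(F)F)cc1)Nc1ccc2nc(N3CCCC3)ccc2c1` has two entries of its own, and in this assay compound 3 gives 3 nM; 3 nM (2 entries) each time. Compound 4 `O=C(CCc1ccc(C(F)(F)F)cc1)Nc1ccc2nc(N3CC4CCC3CC4)ccc2c1` has not yet been measured; it differs from compound 2 on an aromatic carbon of the shared core, where (a group of 8 heavy atoms (7 carbon, 1 nitrogen; 2 six-membered non-aromatic rings with 1 hetero atom each) in place of a group of 3 heavy atoms (2 carbon, 1 nitrogen; no ring), on an aromatic carbon). For the measured compounds named here, the only step of one change that is on record, from compound 1 to compound 2, exchanges one cyclic amine for dimethylamino and stays inside the scatter; no measured pair speaks to the bridged bicyclic amine of compound 4. The reference points are thus the three values above, all spanning a narrow window. Compound 4 is expected to give 10 nM, with a plausible range from 3 nM to 40 nM. The estimated step of a 1.3-fold lower number from compound 2 to compound 4 (0.11 log units; within the scatter) is therefore expected to be one not beyond the scatter.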

Compound 4, half-maximal inhibitory concentration: 3 nM
Beside the measured number, compound 4's estimate is 3.3-fold (0.52 log units) above it; the range from low to high includes it.
By their numbers in this assay, from the lowest: compound 4; then compounds 2 and 1 (each within the scatter of the next).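

In this assay, for the compounds shown here, replacing dimethylamino on the aromatic carbon next to the ring nitrogen with the bridged amine gives the first step at this position that lies beyond the scatter, a 4.3-fold lower number from compound 2 to compound 4 (0.64 log units; beyond the scatter). Replacing the 3-phenylpyrrolidin-1-yl group with the same bridged amine gives an 8.3-fold lower number from compound 1 to compound 4 (0.92 log units; beyond the scatter), so among compounds 1, 2 and 4 the lowest number belongs to the group of intermediate heavy-atom count, and the number does not follow group size. The bridged amine also matches the cyclic amine of compound 3, which gives 3 nM; 3 nM (2 entries), since compound 4 gives 3 nM.

No evidence here bears on what lies behind these steps. On these data alone, it remains open whether a morpholine or a piperidine on the same carbon would give a number as low.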